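Phenyl to chloro on the series' aromatic ring

A few compounds are considered here, and "the series" means these few. Any claim that something is new, unique, unknown or untested is made for them only; others in the source may bear on it.

Among the compounds with values here, in a functional assay on HCT-116 cells (Homo sapiens) for inhibition, read by colorimetric assay, with a stated time of 3 days (a higher number here means a weaker inhibitor, a lower number a stronger inhibitor), compound 2 `O=C(CCCCCCNC(=O)C(O)(O)C(F)(F)F)Nc1ccc(-c2ccccc2)cc1` gives 4730 nM and holds the lowest of the two numbers so far. Within the data shown here, compound 1 `CC(=O)c1ccc(NC(=O)CCCCCCNC(=O)C(O)(O)C(F)(F)F)cc1` gives 12100 nM in this assay and is its only neighbour. Compound 3 `O=C(CCCCCCNC(=O)C(O)(O)C(F)(F)F)Nc1ccc(Cl)cc1` is next, with this change from compound 2: chloro in place of phenyl on an aromatic carbon. Among the measured compounds shown here, one measured step bears on it: a 2.6-fold lower number from compound 1 to compound 2 (0.41 log units; beyond the scatter) with phenyl in place of acetyl on an aromatic carbon, a modest step beyond the scatter. For the measured compounds named here, no chloro analogue has been measured, and two compounds set no trend. Losing the phenyl may give back part of that step, so a small move toward a higher number is expected, possibly no larger than the scatter. The expected move is a 1.7-fold higher number from compound 2 to compound 3 (0.23 log units; within the scatter) as an estimate only. Compound 3 is estimated at 8000 nM with an expected range from 3500 nM to 18000 nM (estimate).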

Compound 3, half-maximal inhibitory concentration: 4230 nM
Beside the measured number, compound 3's estimate is 1.9-fold (0.28 log units) above it, and the stated range covers the measured number.
By their numbers in this assay, from the lowest: compounds 3 and 2 (each within the scatter of the next); then compound 1.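

In this assay, chloro in place of phenyl on this aromatic carbon gives a 1.1-fold lower number from compound 2 to compound 3 (0.05 log units; within the scatter), so one chlorine atom and a six-carbon aromatic ring cannot be told apart here. Chloro in place of acetyl gives a 2.9-fold lower number from compound 1 to compound 3 (0.46 log units; beyond the scatter), which places chloro with phenyl on the same side of acetyl and shows that the separation from compound 1 does not require a second aromatic ring at this position. No data on why these groups read as they do are available.

From the compounds shown here alone, whether an amine, a carboxylic acid or a methoxy group on this aromatic carbon would read with chloro and phenyl or with acetyl remains open. Going by these compounds, all three compounds share the same chain, so the effect of a longer chain or a shorter one on these readings is also open.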